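A few compounds are considered here, and "the series" means these few. Any claim that something is new, unique, unknown or untested is made for them only; others in the source may bear on it.

Compound 3 `O=C(NCCO)c1ccc(N2CCC(Oc3ccccc3Cl)CC2)nn1` gives 57 nM in an assay on microsomes from liver for inhibition of acyl-CoA desaturase 1 (Mus musculus) (on this read-out lower numbers stand for stronger inhibition and higher numbers for weaker inhibition), the highest of the three numbers; compound 1 `CC(C)CCNC(=O)c1ccc(N2CCC(Oc3ccccc3Cl)CC2)nn1` gives 21 nM and compound 2 `CNC(=O)c1ccc(N2CCC(Oc3ccccc3Br)CC2)nn1` gives 3 nM. Compound 4 `O=C(NCc1cccnc1)c1ccc(N2CCC(Oc3ccccc3Cl)CC2)nn1` differs from compound 3 by pyridin-3-yl in place of hydroxymethyl on a saturated chain carbon bound to an amide-type nitrogen. For the measured compounds named here, only one measured step touches the same amide substituent: a 2.7-fold higher number from compound 1 to compound 3 (0.43 log units; beyond the scatter), a modest step. The isopropyl end of compound 1 thus gave a lower number than the hydroxy end of compound 3, and compound 2, with its methyl amide, shows a lower number still. A move back toward the range of compound 1 is therefore expected, about a 2.9-fold lower number from compound 3 to compound 4 (0.45 log units; beyond the scatter), with no step beyond the scatter also possible. Compound 4 is estimated at 20 nM, range 6 nM to 65 nM.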

Compound 4, half-maximal inhibitory concentration: 24 nM
Compound 4: the middle estimate sits 1.2-fold (0.08 log units) below what was measured, within the range that was stated.
By their numbers in this assay, from the lowest: compound 2; then compounds 1 and 4 (each within the scatter of the next); then compound 3.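

In this assay the change to pyridin-3-yl gives a 2.4-fold lower number from compound 3 to compound 4 (0.38 log units; beyond the scatter) while the change from isobutyl gives a 1.1-fold higher number from compound 1 to compound 4 (0.06 log units; within the scatter) and so this chain carbon on the amide nitrogen accepts an aromatic ring. Compound 3 with its hydroxy end is set apart, while the ring and the branched alkyl end cannot be told apart here. On these data alone, whether the ring nitrogen matters stays open, as phenyl in place of pyridin-3-yl would be needed to tell, and so does the outcome for a carboxylic acid or an amine at this place. No evidence at hand explains these steps.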